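Morpholine in place of piperidine: what to expect for compound 4

The source may hold more compounds than are shown below. What is called first, only, known or untested is meant among the compounds shown, and "the series" means these compounds.

Three measured compounds share one core and differ only in the aryl group. In an assay on CHO-K1 cells for antagonist activity at adenosine receptor A1 (Homo sapiens), read by a beta-galactosidase reporter, with stated times of 15 min and 6 h (a higher number here means a weaker inhibitor, a lower number a stronger inhibitor), compound 1 `C[C@@H]1CCC[C@H](C)N1Cc1cc2c(N)nc(-c3ccc(C4CC4)o3)nc2s1` gives 330 nM; compound 2 `Cc1csc(-c2nc(N)c3cc(CN4[C@H](C)CCC[C@@H]4C)sc3n2)n1` gives 300 nM; compound 3 `C[C@@H]1CCC[C@H](C)N1Cc1cc2c(N)nc(-c3cccc(C#N)c3)nc2s1` gives 460 nM. Compound 3 carries the highest of the three numbers, but the gaps to the other two are within the scatter, as a 1.4-fold higher number from compound 1 to compound 3 (0.14 log units; within the scatter) and a 1.5-fold higher number from compound 2 to compound 3 (0.19 log units; within the scatter) show; likewise a 1.1-fold lower number from compound 1 to compound 2 (0.04 log units; within the scatter) stays within the scatter. Compound 4 `C[C@@H]1CN(Cc2cc3c(N)nc(-c4cccc(C#N)c4)nc3s2)C[C@H](C)O1` keeps the aryl group of compound 3 and changes the other end: 2,6-dimethylmorpholin-4-yl in place of 2,6-dimethylpiperidin-1-yl on a saturated chain carbon bound to an aromatic carbon. For the measured compounds named here, none of the measured steps touches this place, so no step in this assay bears on the change. With nothing to lean on, the expected step is a 1.3-fold higher number from compound 3 to compound 4 (0.12 log units; within the scatter), carrying a wide range. The estimate for compound 4 in this assay is 600 nM, from 150 nM to 2500 nM.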

Compound 4, inhibition constant: 1070 nM
For compound 4 the middle estimate is 1.8-fold (0.25 log units) below the measured one, and the stated range covers the measured number.
By their numbers in this assay, from the lowest: compounds 2, 1 and 3 (each within the scatter of the next); then compound 4.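

In this assay this position, on a saturated chain carbon bound to an aromatic carbon, gives the only single change shown that goes beyond the scatter: a 2.3-fold higher number from compound 3 to compound 4 (0.37 log units; beyond the scatter) with 2,6-dimethylmorpholin-4-yl in place of 2,6-dimethylpiperidin-1-yl. The aryl swaps among compound 1, compound 2 and compound 3 all stay within the scatter. No data at hand account for this step.

Open, from the compounds shown here alone, is whether the step carries over to the 5-cyclopropylfuran-2-yl and 4-methyl-1,3-thiazol-2-yl compounds. Also open, going by these compounds, is how a piperazine or an unsubstituted morpholine would read at this place.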